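From 5-oxopyrrolidin-2-yl to 6-oxopiperidin-2-yl in compound 3

The source may report more compounds than this note shows. Statements on the series, on what has been measured and on what is new or still open speak of the compounds shown alone.

Measured so far in a functional assay on NCI-H460 cells (Homo sapiens) for cytotoxicity, read by sulforhodamine B assay, with a stated time of 24 h; a higher number here means a weaker inhibitor, a lower number a stronger inhibitor:
Compound 1 `CC(=O)SCCCCC[C@H](NC(=O)[C@H]1CCC(=O)N1)C(=O)Nc1cccc(C(F)(F)F)c1` gives 30 nM
Compound 2 `CC(=O)SCCCCC[C@H](NC(=O)[C@@H]1CCC(=O)N1)C(=O)Nc1cccc(C)c1` gives 60 nM

In this assay compound 2 gives 60 nM and lies within the usual scatter of compound 1 at 30 nM so these two results cannot be ranked. Compound 3 `CC(=O)SCCCCC[C@H](NC(=O)[C@@H]1CCCC(=O)N1)C(=O)Nc1cccc(C)c1` has not yet been measured. It carries 6-oxopiperidin-2-yl in place of 5-oxopyrrolidin-2-yl on a carbonyl carbon and is otherwise the same as compound 2. Going by the values given here, no two measured compounds differ in one place only, so no measured step bears directly on this change. An estimated 1.3-fold higher number from compound 2 to compound 3 (0.12 log units; within the scatter) is expected in this assay as a small move toward a higher number, one not expected to exceed the scatter. For compound 3 the estimated value is 80 nM with an expected range from 25 nM to 250 nM in this assay.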

Compound 3, half-maximal inhibitory concentration: 60 nM
Beside the measured number, compound 3's estimate is 1.3-fold (0.12 log units) above it; the measured number falls inside the stated range.
By their numbers in this assay, from the lowest: compounds 1, 2 and 3 (each within the scatter of the next).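

In this assay, going by these compounds alone, the change gives no change at the digits printed from compound 2 to compound 3 (within the scatter), the first comparison that alters one place only. On a carbonyl carbon whose other neighbour is an amide-type nitrogen, the six-membered non-aromatic ring of 6-oxopiperidin-2-yl therefore stands in for the five-membered ring of 5-oxopyrrolidin-2-yl with no readable difference in this cytotoxicity measure. Nothing available explains this result.

The compounds shown leave open whether an open-chain amide, a carboxylic acid or an amine at this place would give a similar number, and whether a seven-membered lactam would do so. On these data alone, it also remains open whether the same exchange would read alike on the core of compound 1, which differs from compound 2 in more than one place.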